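Working notes: the step from compound 3 to compound 4

The source may hold more compounds than are shown below. What is called first, only, known or untested is meant among the compounds shown, and "the series" means these compounds.

Measured so far in a functional assay on Huh-7 cells (Homo sapiens) for cytotoxicity, read by MTT assay, with a stated time of 3 days; a lower number here means that less compound is tolerated, a higher number that more compound is tolerated:
compound 1 `OC[C@H]1O[C@@H](n2cnc3c(Cn4ccc5ccccc54)ncnc32)[C@H](O)[C@@H]1O` gives > 250000 nM as a limit
compound 2 `O=C(O)CNCc1ncnc2c1ncn2[C@@H]1O[C@H](CO)[C@@H](O)[C@H]1O` gives > 100000 nM as a limit
compound 3 `OC[C@H]1O[C@@H](n2cnc3c(CN4CCCCC4)ncnc32)[C@H](O)[C@@H]1O` gives 87000 nM as a number

Going by the values given here, compound 3 holds the only actual number in the set, since the other two values are limits. The series shows an at least 2.8-fold lower number from compound 1 to compound 3 (0.45 log units; beyond the scatter) and it also shows an at least 1.1-fold lower number from compound 2 to compound 3 (0.06 log units; that floor lies within the scatter) so compound 3 sits clearly under compound 1 only.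

Compound 4 `O=C(O)CSCc1ncnc2c1ncn2[C@@H]1O[C@H](CO)[C@@H](O)[C@H]1O` departs from compound 3 as follows: (carboxymethyl)sulfanyl in place of piperidin-1-yl on a saturated chain carbon bound to an aromatic carbon that is, (carboxymethyl)sulfanyl in place of piperidin-1-yl on a saturated chain carbon bound to an aromatic carbon. Among the compounds with values here, no measured compound carries this group. The nearest measured comparison is compound 2, which has (carboxymethyl)amino at the same place, and the step there is an at least 1.1-fold lower number from compound 2 to compound 3 (0.06 log units; that floor lies within the scatter) which sets only a floor within the scatter. The step of an at least 2.8-fold lower number from compound 1 to compound 3 (0.45 log units; beyond the scatter) involves neither group of compound 4 and bears on it only loosely.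

Compound 4 is therefore expected to resemble compound 2 more than compound 3, with a small move to a higher number in this assay that may not clear the scatter. The expected change is a 1.7-fold higher number from compound 3 to compound 4 (0.24 log units; within the scatter) in the direction of more compound tolerated. For compound 4 the estimated half-maximal cytotoxic concentration is 150000 nM with an expected range of 70000 nM to 300000 nM and a report of only a limit would not be surprising.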

Compound 4, half-maximal cytotoxic concentration: > 100000 nM
Compound 4 gave a limit, no number; the forecaster's own chance of this, stated with the estimate: 65%; the middle value lies beyond the limit too.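

In this assay, the exchange of piperidin-1-yl for (carboxymethyl)sulfanyl on a saturated chain carbon bound to an aromatic carbon can be read only as a floor: an at least 1.1-fold higher number from compound 3 to compound 4 (0.06 log units; that floor lies within the scatter). The two carboxymethyl groups at this place, the (carboxymethyl)amino of compound 2 and the (carboxymethyl)sulfanyl of compound 4, now end at one shared limit, which is a limit and not a number: the limit of > 100000 nM in this assay, at which 2 of the 4 values shown sit. The steps from compound 1 and from compound 2 to compound 4 join two limits and cannot be read, so the exchange of the nitrogen-linked group for the sulfur-linked one remains unresolved.

On these data alone, whether compound 4 lies close to compound 3 or far from it in this assay stays open, since the printed floor does not separate the two compounds beyond the scatter. Also open, as far as these compounds go, is how a (2-carboxyethyl)sulfanyl group, with its longer chain, or the methyl ester of the (carboxymethyl)sulfanyl group would read at this place on the shared core.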